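The compounds below may be only part of what the source reports. "The series", "measured", "known", "first", "only" and "open" are said of these compounds alone.

Measured so far in a functional assay on A549 cells (Homo sapiens) for antiproliferative activity, read by MTT assay, with a stated time of 24 h; on this read-out lower numbers stand for stronger inhibition and higher numbers for weaker inhibition:

- compound 1 `CNC(=O)c1ccccc1Oc1nc(Nc2ccc(Br)cc2)ncc1Br`: 23500 nM
- compound 2 `CNC(=O)c1ccccc1Oc1nc(Nc2ccc(Cl)cc2F)ncc1Br`: 38100 nM

Among the compounds with values here, compound 2 has only one measured neighbour, compound 1, and the one step between them, a 1.6-fold higher number from compound 1 to compound 2 (0.21 log units; within the scatter), is within the scatter; on this evidence the two compounds cannot be separated, and compound 2 sits with compound 1 at the weak end of what this assay has returned.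

Compound 3 `CNC(=O)c1ccccc1Oc1nc(Nc2cccc(C(C)C)c2)ncc1Br` is the next point. The change is 3-isopropylphenyl in place of 4-chloro-2-fluorophenyl on a nitrogen on an aromatic ring. Within the data shown here, the only measured step on the series sits at the same place, a 1.6-fold higher number from compound 1 to compound 2 (0.21 log units; within the scatter), and that exchange of one halogenated phenyl for another did not move the number beyond the scatter. No measured step covers an unsubstituted phenyl carrying an alkyl group, so nothing shown points to a move in either direction in this assay. Among the measured compounds shown here, the expectation is therefore a step of a 1.2-fold lower number from compound 2 to compound 3 (0.08 log units; within the scatter), within the scatter, with wide uncertainty because the only precedent is a 1.6-fold higher number from compound 1 to compound 2 (0.21 log units; within the scatter).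

Compound 3 is estimated at 32000 nM, with a range of 10000 nM to 100000 nM in this assay.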

Compound 3, half-maximal inhibitory concentration: 7140 nM
Beside the measured number, compound 3's estimate is 4.5-fold (0.65 log units) above it, and the stated range ends above it.
By their numbers in this assay, from the lowest: compound 3; then compounds 1 and 2 (each within the scatter of the next).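

In this assay, the group on a nitrogen on an aromatic ring can move the number beyond the scatter: the change gives a 5.3-fold lower number from compound 2 to compound 3 (0.73 log units; beyond the scatter), and against the other halogenated phenyl it gives a 3.3-fold lower number from compound 1 to compound 3 (0.52 log units; beyond the scatter), both modest steps. The earlier exchange, a 1.6-fold higher number from compound 1 to compound 2 (0.21 log units; within the scatter), gave no sign of this, so the position is not indifferent to what it carries, and 3-isopropylphenyl, with only carbon among its heavy atoms, gives a lower number than either the 4-bromophenyl or the 4-chloro-2-fluorophenyl group. No measurement shown bears on why the number moves at this position.

The change removes the halogens, brings in an alkyl group and alters the substitution pattern in a single step, so the compounds shown cannot assign the lower number to any one of these differences. On these data alone, it also remains open how an unsubstituted phenyl, a tert-butyl group, or an amine or carboxylic acid on the phenyl would read in this assay, and whether the number can fall further than the modest steps seen here.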